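Three Sulfide Amides and a Naphthyl Newcomer

The source may report more compounds than this note shows. Statements on the series, on what has been measured and on what is new or still open speak of the compounds shown alone.

The three compounds measured so far:
compound 1, `Nc1ccccc1NC(=O)c1ccc(CSc2nccc(C(F)(F)F)n2)cc1`, gives 54.4% in a functional assay on A-375 cells (Homo sapiens) for inhibition, read by CCK-8 assay, with a stated time of 72 h, tested at 2 uM; on this read-out higher numbers stand for more inhibition of growth at the one concentration tested and lower numbers for less inhibition of growth
compound 2, `Nc1ccccc1NC(=O)/C=C/c1ccc(CSc2ccc(Cl)cc2)cc1`, gives 13.4% in this assay
compound 3, `Nc1ccccc1NC(=O)c1ccc(CSc2cccc(F)c2)cc1`, gives 37.7% in this assay

Compound 2 holds the lowest of the three numbers. Its nearest neighbour is compound 3, which lies above it by a gap beyond the usual scatter, and compound 1 lies further above still, also beyond the scatter. Compound 2 is also the only one of the three that carries the unsaturated linker between the carbonyl and the central ring, so its low number cannot be tied to any single feature from these data alone.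

Compound 4, `Nc1ccccc1NC(=O)/C=C/c1ccc(CSc2cccc3ccccc23)cc1`, is the next compound to be tested in this assay. It keeps everything of compound 2 except one group: naphthalen-1-yl in place of 4-chlorophenyl on a sulfur.

Within the data shown here, no measured pair shows the effect of such a swap, so the direction of the step cannot be read from the other compounds. With a larger group entering on the sulfur and the rest of compound 2 unchanged, the expected step is small, near the scatter, and likely upward. The expected step from compound 2 to compound 4 is a number 8.6 percentage points higher from compound 2 to compound 4 (within the scatter). Compound 4 is therefore estimated to give 22%, with a range from 5% to 42%.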

Compound 4, percent growth inhibition at one concentration: 1.55%
Beside the measured number, compound 4's estimate is 20.5 percentage points above it; measured number outside the range, below it.
By their numbers in this assay, from the lowest: compound 4; then compound 2; then compound 3; then compound 1.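

Among these compounds, this pair is the first in the set that differs in one place only, and it shows that the group on the sulfur does affect the number in this assay: naphthalen-1-yl in place of 4-chlorophenyl, with everything else unchanged, gives a number 11.9 percentage points lower from compound 2 to compound 4 (beyond the scatter). A larger all-carbon group with two six-membered aromatic rings therefore did not raise growth inhibition at this position, at least with the unsaturated linker present. The swap removes the chlorine and adds a second aromatic ring in a single step, and no measurement shown here explains the fall or assigns it to either of these changes.

From the compounds shown here alone, whether the same swap would give a similar step in compounds with the carbonyl attached directly to the central ring, such as compound 3, remains open, as does the effect of the unsaturated linker on its own. A plain phenyl group on the sulfur, with no chlorine, could help separate the loss of the chlorine from the gain of the second ring, while a pyridin-2-yl group would test a ring containing nitrogen at the same place.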